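Adding an Amino Group to Compound 2

The source may report more compounds than this note shows. Statements on the series, on what has been measured and on what is new or still open speak of the compounds shown alone.

In an ADME assay on MT4 cells (Homo sapiens) for cytotoxicity, read by MTT assay (a lower number here means that less compound is tolerated, a higher number that more compound is tolerated), compound 1 `Cc1c(N)nc(Nc2ccc(C#N)cc2)nc1Cc1c(F)cccc1F` gives 45900 nM and compound 2 `Cc1cnc(Nc2ccc(C#N)cc2)nc1C(C)c1c(F)cccc1F` gives 71400 nM, two values within the usual scatter of each other. Compound 3 `CC(c1cc(=O)[nH]c(Nc2ccc(C#N)cc2)n1)c1c(F)cccc1F` gives > 2830 nM, which is a limit and not a number. Compound 4 `Cc1c(N)nc(Nc2ccc(C#N)cc2)nc1C(C)c1c(F)cccc1F` has amino in place of hydrogen on an aromatic carbon of compound 2, next to the ring nitrogen and ortho to a methyl group: amino in place of hydrogen on an aromatic carbon. Within the data shown here, no measured pair isolates this change. Compound 1, which also carries an amino group, gives 45900 nM, and on that basis no change beyond the scatter is expected in this assay. The expected step is a 1.4-fold lower number from compound 2 to compound 4 (0.15 log units; within the scatter). For compound 4, the estimated value is 50000 nM, within an expected range of 15000 nM to 130000 nM.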

Compound 4, half-maximal cytotoxic concentration: 40500 nM
Estimate against measurement, compound 4: 1.2-fold (0.09 log units) above; the measured number falls inside the stated range.
By their numbers in this assay, from the lowest: compounds 4, 1 and 2 (each within the scatter of the next).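

In this assay, amino in place of hydrogen on this aromatic carbon, next to the ring nitrogen and ortho to a methyl group, now has a direct reading: a 1.8-fold lower number from compound 2 to compound 4 (0.25 log units; within the scatter) for this change. With the amino group present, methyl in place of hydrogen on the saturated chain carbon bound to two aromatic carbons gives a 1.1-fold lower number from compound 1 to compound 4 (0.05 log units; within the scatter) in the same assay. No measurement shown bears on a cause for these steps. Going by these compounds, whether a dimethylamino group, a hydroxyl group or a carboxylic acid on this aromatic carbon would also stay within the scatter of compound 2 remains open.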